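A few compounds are considered here, and "the series" means these few. Any claim that something is new, unique, unknown or untested is made for them only; others in the source may bear on it.

Measured compounds:
- compound 1, `COc1ccc(-c2cc3c(N[C@H](CO)CC(C)C)c(C(N)=O)cnn3c2)cn1`: in a functional assay on cells (T-cell, Homo sapiens) for inhibition, read by scintillation counting and thymidine incorporation, with stated times of 60 min and 3 days (on this read-out lower numbers stand for stronger inhibition and higher numbers for weaker inhibition), compound 1 gives 190 nM
- compound 2, `COc1ccc(-c2cc3c(NC(CO)[C@H](O)C4CC4)c(C(N)=O)cnn3c2)cn1`: in this assay compound 2 gives 4800 nM; 500 nM (2 entries)

Compound 1 holds the only single number shown in this assay; a further entry for it carries no single number. Compound 2 has several entries, and these scatter widely, (the several entries of compound 2 in this assay, 4800 nM; 500 nM (2 entries)), with both sitting higher than the number for compound 1. The next compound, compound 3, `COc1ccc(-c2cc3c(N[C@H](CO)[C@@H](C)O)c(C(N)=O)cnn3c2)cn1`, is built from compound 1 by a single change: 1-hydroxyethyl in place of isobutyl on a saturated chain carbon bound to a nitrogen on an aromatic ring and a saturated chain carbon. Among the measured compounds shown here, no measured pair isolates this exact change, so the expectation rests on compound 1 together with the spread seen for compound 2, whose side chain also carries a hydroxyl. A step toward weaker inhibition is expected, larger than the usual scatter, a 4.7-fold higher number from compound 1 to compound 3 (0.68 log units; beyond the scatter). Compound 3 is therefore estimated at 900 nM, likely between 300 nM and 3000 nM.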

Compound 3, half-maximal inhibitory concentration: 370 nM
Compound 3: middle estimate off by 2.4-fold (0.39 log units), on the high side, within the range that was stated.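

In this assay, the step reads a 1.9-fold higher number from compound 1 to compound 3 (0.29 log units; within the scatter), so on a saturated chain carbon bound to a nitrogen on an aromatic ring and a saturated chain carbon, the all-carbon isobutyl and 1-hydroxyethyl, with its hydrogen-bond donor and acceptor, cannot be told apart. This place therefore accepts a hydroxyl-bearing group without a step beyond the usual scatter, at least in this one pair. Compound 2 also carries a hydroxyl on its side chain, but it remains a loose guide to such groups: the several entries of compound 2 in this assay, 4800 nM; 500 nM (2 entries)

On these data alone, the swap alters chain size and adds a hydroxyl at once, so the contribution of each remains unknown; a plain ethyl group would help to separate them. Also open, as far as these compounds go, are how an amine at this place would read and whether the defined stereocentre of 1-hydroxyethyl matters.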